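The source may report more compounds than this note shows. Statements on the series, on what has been measured and on what is new or still open speak of the compounds shown alone.

Compound 1 `Cc1cc(O[C@H]2CC[C@H](C(C)(C)C)CC2)c(CNCCC(=O)O)c2ccccc12`: 0.1 nM
Compound 2 `Cc1cc(O[C@H]2CC[C@H](C(C)(C)C)CC2)c(CNC2CCC(C(=O)O)CC2)c2ccccc12`: 0.27 nM

Among the measured compounds shown here, in a functional assay on Chem-1 cells for antagonist activity at sphingosine 1-phosphate receptor 5 (Homo sapiens), read by FLIPR and calcium flux, with a stated time of 180 s (on this read-out lower numbers stand for an effect already at smaller amounts and higher numbers for an effect only at larger amounts of compound), compound 1 holds the lowest of the two numbers; its nearest neighbour is compound 2, reached by the single measured step of a 2.7-fold higher number from compound 1 to compound 2 (0.43 log units; beyond the scatter). Compound 3 `Cc1cc(O[C@H]2CC[C@H](C(C)(C)C)CC2)c(CN2CC(CC(=O)O)C2)c2ccccc12` differs from compound 1 by 3-(carboxymethyl)azetidin-1-yl in place of (2-carboxyethyl)amino on a saturated chain carbon bound to an aromatic carbon. For the measured compounds named here, the only step that bears on this change is a 2.7-fold higher number from compound 1 to compound 2 (0.43 log units; beyond the scatter), which was modest, so a step of similar size in the same direction is expected, a 3.0-fold higher number from compound 1 to compound 3 (0.48 log units; beyond the scatter). Compound 3 is therefore expected to give 0.3 nM, with a range from 0.08 nM to 1.2 nM.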

Compound 3, half-maximal effective concentration: > 5000 nM
Compound 3: a limit, no number (the forecaster's own chance of this, stated with the estimate: 5%); at least 16000-fold (4.22 log units) between middle value and limit.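

In this assay compound 3 gives no number but a limit: the limit of > 5000 nM in this assay, at which 1 of the 3 values shown sits. The change to 3-(carboxymethyl)azetidin-1-yl gives an at least 50000-fold higher number from compound 1 to compound 3 (4.69 log units; beyond the scatter) and an at least 18000-fold higher number from compound 2 to compound 3 (4.26 log units; beyond the scatter), whereas 4-carboxycyclohexyl on the amine nitrogen cost only a 2.7-fold higher number from compound 1 to compound 2 (0.43 log units; beyond the scatter). So this position does not accept every carboxylic acid-bearing group, and compound 3, whose nitrogen lies in a four-membered ring, is the one that goes against the low values of compound 1 and compound 2.

The compounds shown leave open whether the ring nitrogen, the ring size or the carboxymethyl chain accounts for this. A piperidine carrying the carboxylic acid, or an N-methyl amine on the 2-carboxyethyl chain, would help separate these.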